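A few compounds are considered here, and "the series" means these few. Any claim that something is new, unique, unknown or untested is made for them only; others in the source may bear on it.

Measured compounds:
- compound 1 `CCCCN(CCC)c1nc(C)nc2c(-c3c(C)cc(N(C)C)nc3C)c(C)nn12` — 12.8 nM
- compound 2 `CCC(CC)Nc1nc(C)nc2c(-c3ccc(OC)nc3C)c(C)nn12` — 3.1 nM
- compound 3 `CCCN(CCC)c1nc(C)nc2c(-c3c(C)cc(N(C)C)nc3C)c(C)nn12` — 14.9 nM

In an assay on cell membranes for displacement of a labelled ligand from corticotropin-releasing factor receptor 1 (Rattus norvegicus) (on this read-out higher numbers stand for weaker inhibition and lower numbers for stronger inhibition), compound 2 gives the lowest number of the three, and its gaps to compound 1 and compound 3 both lie beyond the scatter. Compound 4 `CCCCN(CCC)c1nc(C)nc2c(-c3ccc(OC)nc3C)c(C)nn12` differs from compound 2 by butyl(propyl)amino in place of (pentan-3-yl)amino on an aromatic carbon. For the measured compounds named here, only one measured step touches this part of the molecules: a 1.2-fold higher number from compound 1 to compound 3 (0.07 log units; within the scatter), which concerns the chain on that nitrogen alone. Going by the values given here, no measured pair shows the secondary amine of compound 2 against a tertiary amine on the same core, so the size of the exchange itself is unknown. Because compound 2 gives 3.1 nM while the tertiary amines of compound 1 and compound 3 give weaker numbers, a modest weakening is expected, as a 2.1-fold higher number from compound 2 to compound 4 (0.32 log units; beyond the scatter). Compound 4 is estimated at 6.5 nM, with a range from 2 nM to 20 nM.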

Compound 4, half-maximal inhibitory concentration: 2.4 nM
For compound 4 the middle estimate is 2.7-fold (0.43 log units) above the measured one; the measured number falls inside the stated range.
By their numbers in this assay, from the lowest: compounds 4 and 2 (each within the scatter of the next); then compounds 1 and 3 (each within the scatter of the next).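

In this assay the exchange on this aromatic carbon gives a 1.3-fold lower number from compound 2 to compound 4 (0.11 log units; within the scatter), so the secondary amine and the tertiary amine cannot be told apart here. The hydrogen-bond donor of (pentan-3-yl)amino is absent from butyl(propyl)amino, which also has more heavy atoms, yet the two compounds stand level; the earlier step had varied only a chain on a tertiary amine. Nothing available explains this result. From the compounds shown here alone, whether a ring amine such as morpholine, or a chain carrying an ether oxygen, would hold this level remains open.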